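Replacing a Dihydroxyphenyl Group in Melanoma Growth Inhibition

A few compounds are considered here, and "the series" means these few. Any claim that something is new, unique, unknown or untested is made for them only; others in the source may bear on it.

Of the compounds shown here, three have been measured in a functional assay on cells (Melanoma cell, Homo sapiens) for cytotoxicity, read by sulforhodamine B assay, with a stated time of 48 h; a higher number here means a weaker inhibitor of growth, a lower number a stronger inhibitor of growth. Compound 1 `NS(=O)(=O)c1ccc(-n2nc(-c3ccc(Cl)cc3)cc2-c2cc(O)ccc2O)cc1` gives 38900 nM. Compound 3 `NS(=O)(=O)c1ccc(-n2nc(-c3ccc(Cl)cc3)cc2C2=CC(=O)C=CC2=O)cc1` gives 52700 nM. Compound 2 `CC(=O)NS(=O)(=O)c1ccc(-n2nc(-c3ccccc3)cc2-c2cc(O)ccc2O)cc1` gives 100000 nM, the highest of the three numbers; its gap to compound 3 is within the scatter, while its gap to compound 1 lies beyond it. The difference between the cores of compound 1 and compound 2 is not broken down here.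

Compound 1 and compound 3 differ in one place: a group of 8 heavy atoms (6 carbon, 2 oxygen; one six-membered non-aromatic ring of carbon only) in place of a group of 8 heavy atoms (6 carbon, 2 oxygen; one six-membered aromatic ring of carbon only), on an aromatic carbon The step is a 1.4-fold higher number from compound 1 to compound 3 (0.13 log units; within the scatter), which is within the scatter.

Compound 4 `CC(=O)NS(=O)(=O)c1ccc(-n2nc(-c3ccccc3)cc2C2=CC(=O)C=CC2=O)cc1` is not yet measured. It relates to compound 2 as compound 3 relates to compound 1: a group of 8 heavy atoms (6 carbon, 2 oxygen; one six-membered non-aromatic ring of carbon only) in place of a group of 8 heavy atoms (6 carbon, 2 oxygen; one six-membered aromatic ring of carbon only), on an aromatic carbon The surroundings are not the same word for word: in compound 2 the group sits next to the ring atom that bears a large group and two ring bonds from the ring atom that bears a phenyl group, whereas in compound 1 those ring atoms bear a 4-sulfamoylphenyl group and a 4-chlorophenyl group. It is therefore the same kind of change, not the same change.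

The step from compound 2 to compound 4 is expected to be no change at the digits printed from compound 2 to compound 4 (within the scatter), set beside the earlier one; this expectation rests on the step of a 1.4-fold higher number from compound 1 to compound 3 (0.13 log units; within the scatter). Since compound 2 already stands at the top of the measured range, compound 4 may well register only as a limit in this assay. Compound 4 is expected to give about 100000 nM in this assay, most likely between 50000 nM and 200000 nM.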

Compound 4, concentration for total growth inhibition: 100000 nM
Compound 4: the middle estimate sits on the measured number at the digits printed; the measured number falls inside the stated range.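

In this assay, putting the non-aromatic six-membered carbon ring in place of the 2,5-dihydroxyphenyl group gives no change at the digits printed from compound 2 to compound 4 (within the scatter). Set beside the same change on the core of compound 1, the result carries over from one core to the other with no difference that stands clear of the scatter: the same change on two cores in this assay, a 1.4-fold higher number (0.13 log units; within the scatter) from compound 1 to compound 3 and no change at the digits printed (within the scatter) from compound 2 to compound 4, 1.4-fold (0.13 log units) apart, within the scatter of two such steps

This shows that, on these two cores, the exchange leaves the reading of growth inhibition within the scatter, so the two groups cannot be told apart in this assay; it does not show that the same would hold on a third core, nor does it give any reason for the agreement, and two cores that differ from each other in more than one place are a narrow basis for a general rule.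

The compounds shown leave open whether a different group in this place, such as a methoxyphenyl ring, an amine or a carboxylic acid, would move the number beyond the scatter. They also leave open how much of the gap between the two cores belongs to the chlorine on the phenyl ring and how much to the acetyl group on the sulfonamide nitrogen, taken one at a time.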